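Acylated trimethoxyanilines in a KYSE-450 cell assay

The source may hold more compounds than are shown below. What is called first, only, known or untested is meant among the compounds shown, and "the series" means these compounds.

Measured compounds:
compound 1, `COc1cc(NCc2ccccc2)cc(OC)c1OC`, > 80000 nM;
compound 2, `COc1ccc(CNc2cc(OC)c(OC)c(OC)c2)cc1[N+](=O)[O-]`, 16800 nM;
compound 3, `COCC(=O)N(Cc1ccc(OC)c(O)c1)c1cc(OC)c(OC)c(OC)c1`, 460 nM.

In a functional assay on KYSE-450 cells (Homo sapiens) for inhibition, read by MTT assay, with a stated time of 48 h (a higher number here means a weaker inhibitor, a lower number a stronger inhibitor), compound 1 gives only a limit, (the limit of > 80000 nM in this assay, at which 1 of the 3 values shown sits). In this assay compound 2 gives 16800 nM. Compound 3 gives the lowest of the two numbers shown, 460 nM, and its distance from compound 2 is beyond the scatter.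

Compound 4, `C=C(C)C(=O)N(Cc1ccc(OC)c(O)c1)c1cc(OC)c(OC)c(OC)c1`, is not yet measured. It differs from compound 3 in one place: 1-methylethenyl in place of methoxymethyl on a carbonyl carbon. Within the data shown here, no step between measured compounds covers such a change. The expected step of a 1.4-fold lower number from compound 3 to compound 4 (0.16 log units; within the scatter) is small, within the scatter, since compound 3 at 460 nM already anchors the series. Compound 4 is therefore estimated at 320 nM, with a range from 80 nM to 1500 nM.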

Compound 4, half-maximal inhibitory concentration: 200 nM
Compound 4: middle estimate off by 1.6-fold (0.20 log units), on the high side, within the range that was stated.
By their numbers in this assay, from the lowest: compound 4; then compound 3; then compound 2. At a limit, above all of these: compound 1.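

In this assay, among these compounds, replacing methoxymethyl with 1-methylethenyl on a carbonyl carbon gives a 2.3-fold lower number from compound 3 to compound 4 (0.36 log units; beyond the scatter) and is the first change at one place that can be read. It shows that this position accepts an all-carbon group with a double bond and that the oxygen of methoxymethyl is not needed for activity in this range. Nothing measured here accounts for the step.

From the compounds shown here alone, whether the double bond itself matters remains open. So does how an amine, a carboxylic acid or a longer chain would read on the same carbonyl carbon.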